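Thioamide side-chain exchange on the shared core

A few compounds are considered here, and "the series" means these few. Any claim that something is new, unique, unknown or untested is made for them only; others in the source may bear on it.

Measured so far:
compound 1 `CC/N=C(\S)CCn1nc(-c2ccccc2)ccc1=O` — 100 mg/kg
compound 2 `Cc1ccc(=O)n(CCC(=N)S)n1` — 43.2 mg/kg

In a functional assay on the whole organism (stomach) with Rattus norvegicus as the target (on this read-out higher numbers stand for an effect only at larger amounts of compound and lower numbers for an effect already at smaller amounts), compound 1 gives 100 mg/kg, the highest of the two numbers at hand. Compound 2 gives 43.2 mg/kg in this assay, a lower number, and the gap to compound 1 lies beyond the usual scatter. Compound 3 `O=c1ccc(-c2ccccc2)nn1CCC(=S)N1CCCC1` differs from compound 1 by a group of 7 heavy atoms (5 carbon, 1 nitrogen, 1 sulfur; one five-membered non-aromatic ring with 1 hetero atom) in place of a group of 5 heavy atoms (3 carbon, 1 nitrogen, 1 sulfur; no ring), on a saturated chain carbon, two bonds along the chain from an aromatic nitrogen. Among the compounds with values here, no step between measured compounds covers such a change, so the direction cannot be read from the data; the expectation for compound 3 is a step of a 1.3-fold lower number from compound 1 to compound 3 (0.10 log units; within the scatter) in this assay, not beyond the scatter. Compound 3 is estimated at 80 mg/kg in this assay, with a range from 30 mg/kg to 250 mg/kg.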

Compound 3, dose for half-maximal effect: > 100 mg/kg
Compound 3 gave a limit, no number; the forecaster's own chance of this, stated with the estimate: 10%; at least 1.2-fold (0.09 log units) between middle value and limit.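

For compound 3, the reading in this assay is a limit, not a number: the limit of > 100 mg/kg in this assay, at which 1 of the 3 values shown sits.

At this saturated chain carbon, the exchange gives a number no lower from compound 1 to compound 3 (the limit leaves the size open). The entering ring group has 0 hydrogen-bond donors against 1 in the group that leaves, and this change brings no lower number in this assay.

The size of the step stays unreadable, so the ring and the donor count cannot be separated as the source of the result. A piperidine ring or an open dimethylamine group at this place remains an open case.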